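Cyclohexyl to 4-Methylphenyl on a Core Without Measured Activity

The source may hold more compounds than are shown below. What is called first, only, known or untested is meant among the compounds shown, and "the series" means these compounds.

Three compounds have been tested in a functional assay on RH7777 cells (Homo sapiens) for antiproliferative activity against RH7777 (Rattus norvegicus), read by sulforhodamine B assay; a lower number here means a stronger inhibitor, a higher number a weaker inhibitor:

Compound 1 `CCCCCCCCCCCCCCCCCCNC(=O)[C@H]1CSC(C2CCCCC2)N1` gives > 20000 nM.
Compound 2 `CCCCCCCCCCCCCCCCCCNC(=O)[C@H]1CSC(Cc2ccccc2)N1` gives > 20000 nM.
Compound 3 `CCCCCCCCCCCCCCCCCCNC(=O)[C@H]1CSC(c2ccc(Br)cc2)N1` gives > 20000 nM.

Each of these three values is a limit of the assay, not a number. Among the compounds with values here, compound 1 therefore stands nowhere on a scale; all that is known is that it sits at the limit, and the limit of > 20000 nM in this assay, at which 3 of the 3 values shown sit, says the same of every value so far. Compound 4 `CCCCCCCCCCCCCCCCCCNC(=O)[C@H]1CSC(c2ccc(C)cc2)N1` differs from compound 1 by 4-methylphenyl in place of cyclohexyl on a saturated ring carbon. Within the data shown here, the steps that bear on this change are a step that the two limits leave unreadable from compound 1 to compound 2 and a step that the two limits leave unreadable from compound 1 to compound 3, and the step that the two limits leave unreadable from compound 2 to compound 3 adds nothing readable either, since every value sits at the limit. No direction and no size can be taken from them, so nothing beyond the scatter can be expected in this assay either way. Compound 4 is estimated to give 30000 nM, within 8000 nM to 100000 nM. The expected step is a step that the limit leaves unreadable from compound 1 to compound 4, most likely ending at the limit once more.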

Compound 4, half-maximal inhibitory concentration: > 20000 nM
Compound 4 was reported as a limit; the forecaster's own chance of this, stated with the estimate: 85%; the middle value is on the limit's open side.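

Compound 4 gives only a limit in this assay, as do compound 1, compound 2 and compound 3, so no step among them can be read: the limit of > 20000 nM in this assay, at which 4 of the 4 values shown sit.

The compounds shown leave open whether changing this group on the shared core affects activity at all.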